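Sulfonyl aryl variation in the enone series

This account rests on a few compounds, and the source may have more. Where it says the series, first, only, none or still open, it means among the compounds named here.

Measured compounds:
compound 1 `COc1ccccc1/C=C(\C(=O)c1ccc(Cl)cc1)S(=O)(=O)c1ccc(C)cc1` 1000 nM
compound 2 `Cc1ccc(S(=O)(=O)/C(=C/c2cccs2)C(=O)c2ccc(Cl)cc2)cc1` 25000 nM
compound 3 `Cc1ccc(S(=O)(=O)/C(=C/c2ccc(Cl)cc2)C(=O)c2ccc(Cl)cc2)cc1` 1000 nM

In a functional assay on DU-145 cells (Homo sapiens) for inhibition, read by trypan blue exclusion, with a stated time of 96 h (on this read-out higher numbers stand for weaker inhibition of growth and lower numbers for stronger inhibition of growth), compound 3 stands level with compound 1 at the digits printed, the two together giving the lowest numbers of the three; the furthest is compound 2, with a 25-fold lower number from compound 2 to compound 3 (1.40 log units; beyond the scatter). The earlier steps shown here all change the group on the double-bonded chain carbon: a 25-fold higher number from compound 1 to compound 2 (1.40 log units; beyond the scatter) and no change at the digits printed from compound 1 to compound 3 (within the scatter) describe that position, and none touches the sulfonyl aryl.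

Compound 4 `O=C(/C(=C\c1ccc(Cl)cc1)S(=O)(=O)c1ccc(Cl)cc1)c1ccc(Cl)cc1` differs from compound 3 by chloro in place of methyl on an aromatic carbon. Among the measured compounds shown here, no measured pair changes this position, so nothing speaks directly to it; the only guidance is that compound 1 and compound 3 sit together while the sulfonyl aryl is held constant. For the measured compounds named here, with no step bearing on the change, the expectation in this assay is no change beyond the scatter, no change at the digits printed from compound 3 to compound 4 (within the scatter). Compound 4 is therefore estimated at 1000 nM, with a range of 300 nM to 3000 nM.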

Compound 4, concentration for 50% growth inhibition: 25000 nM
For compound 4 the middle estimate is 25-fold (1.40 log units) below the measured one; the whole stated range lies below it.
By their numbers in this assay, from the lowest: compounds 1 and 3 (each within the scatter of the next); then compounds 2 and 4 (each within the scatter of the next).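

Among the compounds shown here, the sulfonyl aryl, untouched by the earlier steps, turns out not to be a silent position in this assay: 4-methylphenyl to 4-chlorophenyl gives a 25-fold higher number from compound 3 to compound 4 (1.40 log units; beyond the scatter). This position therefore responds to the exchange of a single heavy atom, chloro in place of methyl, with no ring, hydrogen-bond donor or hydrogen-bond acceptor entering or leaving. No measurement to hand accounts for a step of this size.

Only this one change at the position is shown, and only with 4-chlorophenyl on the double-bonded chain carbon, so whether the step carries over to the 2-methoxyphenyl of compound 1 remains open. Also open, from the compounds shown here alone, is whether a methoxy, an amine or a carboxylic acid in place of the chloro would return a number near that of compound 3, 1000 nM, or stay with compound 4.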